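Replacing the benzofuranyl group with phenoxy in compound 2

The compounds below may be only part of what the source reports. "The series", "measured", "known", "first", "only" and "open" are said of these compounds alone.

Compound 2 `Cc1ccccc1-n1nc(C)c2c1NC(=O)[C@H](C)S[C@@H]2c1ccc(-c2cc3ccccc3o2)cc1` gives 17% in an assay on isolated protein for agonist activity at Bile acid receptor (Homo sapiens), read by AlphaScreen, with a stated time of 30 min (a higher number here means a larger maximal response, a lower number a smaller maximal response), the lowest of the three numbers measured; compound 3 `Cc1nn(-c2ccccc2Br)c2c1C(c1ccc(Oc3ccccc3)cc1)SC(C)C(=O)N2` gives 84% and compound 1 `Cc1nn(-c2ccccc2I)c2c1C(c1ccc(Oc3ccccc3)cc1)SC(C)C(=O)N2` gives 130%, both beyond the scatter above it. Compound 4 `Cc1ccccc1-n1nc(C)c2c1NC(=O)[C@H](C)S[C@@H]2c1ccc(Oc2ccccc2)cc1` differs from compound 2 by phenoxy in place of 1-benzofuran-2-yl on an aromatic carbon. For the measured compounds named here, no measured step covers this exchange; the only measured step, a number 46 percentage points lower from compound 1 to compound 3 (beyond the scatter), concerns a halogen and does not bear on it. Compounds 1 and 3, which both carry phenoxy, show much larger responses than compound 2, so compound 4 is expected to rise by a number 53 percentage points higher from compound 2 to compound 4 (beyond the scatter) in this assay, though with wide uncertainty. Compound 4 is therefore estimated at 70%, between 25% and 120%.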

Compound 4, largest response reached (reported as efficacy), in percent of the reference or control that the assay uses: 118%
Compound 4: middle estimate off by 48 percentage points, on the low side; the range from low to high includes it.
By their numbers in this assay, from the lowest: compound 2; then compound 3; then compound 4; then compound 1.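

In this assay, the exchange at this aromatic carbon, para to a large group, gives a number 101 percentage points higher from compound 2 to compound 4 (beyond the scatter), so the group held here strongly governs the maximal response. The earlier step concerned only a halogen; this one shows that phenoxy and 1-benzofuran-2-yl, though each has one hydrogen-bond acceptor, are far from interchangeable on the same core. Nothing available explains this difference. The compounds shown leave open whether the response depends on the oxygen link or on the single ring, and how a directly attached phenyl or an anilino group would compare.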